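The source may hold more compounds than are shown below. What is called first, only, known or untested is meant among the compounds shown, and "the series" means these compounds.

Compound 1 `CC(C)c1ccc(-c2oc3ccc(C(=O)O)cc3c(=O)c2O)cc1` is one of three measured members of a small series. In a functional assay on the whole organism (stomach) for inhibition, with Rattus norvegicus as the target, at a dose of 80 mg/kg (on this read-out lower numbers stand for less inhibition and higher numbers for more inhibition at the one dose given (going by the name of the read-out)), compound 1 gives 24%. Compound 2 `COc1ccc(-c2oc3ccc(C(=O)O)cc3c(=O)c2O)cc1` differs from it by methoxy in place of isopropyl on an aromatic carbon, and in this assay compound 2 gives 24%; the step of no change at the digits printed from compound 1 to compound 2 (within the scatter) shows that this replacement left the read-out where it was. Compound 3 `CC(C)Oc1c(-c2ccc(C(C)C)cc2)oc2ccc(C(=O)O)cc2c1=O` carries a different core, set apart from compound 1 by isopropyl in place of hydrogen on an oxygen on an aromatic ring; in this assay compound 3 gives 20%, and the step of a number 4 percentage points lower from compound 1 to compound 3 (within the scatter) is likewise within the scatter. All three measured numbers therefore sit in the same region, and none of the compounds can be called stronger or weaker than another on this read-out.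

Compound 4 `COc1ccc(-c2oc3ccc(C(=O)O)cc3c(=O)c2OC(C)C)cc1` has not yet been measured. It relates to compound 3 exactly as compound 2 relates to compound 1: the difference is methoxy in place of isopropyl on an aromatic carbon, and the surroundings of the change are described in the same words for both pairs, so it is the same change made on the core of compound 3. Among the compounds with values here, the only precedent for this change is the step of no change at the digits printed from compound 1 to compound 2 (within the scatter), which produced no shift. On that basis the step of no change at the digits printed from compound 3 to compound 4 (within the scatter) is expected to be flat as well, resting on compound 1 and compound 2 with no change at the digits printed from compound 1 to compound 2 (within the scatter). Compound 4 is therefore estimated at 20% in this assay, most likely between 10% and 30%.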

Compound 4, a percentage reported as inhibition, in the whole organism at one dose (the size of the read-out at that dose, not a potency): 35%
For compound 4 the middle estimate is 15 percentage points below the measured one, outside the stated range (above it).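

In this assay, exchanging 4-isopropylphenyl for 4-methoxyphenyl did not carry over unchanged from one core to the other, since on the core of compound 3 it gave a number 15 percentage points higher from compound 3 to compound 4 (beyond the scatter), which stands apart from its precedent: the same change on two cores in this assay, no change at the digits printed (within the scatter) from compound 1 to compound 2 and a number 15 percentage points higher (beyond the scatter) from compound 3 to compound 4, 15 percentage points apart, beyond the scatter of two such steps

Read the other way round, placing isopropyl on the oxygen did not have the same outcome with the methoxy group present, where it gave a number 11 percentage points higher from compound 2 to compound 4 (beyond the scatter), as it had with the isopropyl group present: the same change on two cores in this assay, a number 4 percentage points lower (within the scatter) from compound 1 to compound 3 and a number 11 percentage points higher (beyond the scatter) from compound 2 to compound 4, 15 percentage points apart, beyond the scatter of two such steps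

Both comparisons rest on the same four compounds, so they show a single dependence of each change on the other, not two separate findings; they do not show why the two changes combine in this way, nor whether this holds for any core beyond these two or at any dose other than the one given.

From the compounds shown here alone, it remains open whether the higher number of compound 4 is tied to isopropyl on the oxygen in particular, or would also appear with an ethyl group or a longer chain there. Going by these compounds, it is equally open how an amine or a chlorine would behave in the place the methoxy group occupies, on either core.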